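Replacing 4-Hydroxyphenyl with an Aminopyrimidine on the Carbonyl

The source may report more compounds than this note shows. Statements on the series, on what has been measured and on what is new or still open speak of the compounds shown alone.

Compound 1 `COc1ccc(-c2cc3ccccc3nc2/C=C/C(=O)c2ccc(O)cc2)cc1`: 3880 nM
Compound 2 `COc1ccc(-c2cc3ccccc3nc2/C=C/C(=O)c2c(OC)cccc2OC)cc1`: 3830 nM

In a functional assay on SK-BR-3 cells (Homo sapiens) for antiproliferative activity, read by XTT assay, with a stated time of 72 h (a higher number here means a weaker inhibitor, a lower number a stronger inhibitor), compound 1 gives 3880 nM, and compound 2 gives 3830 nM; the two stand within the usual scatter of each other, so neither can be called the stronger. Compound 3 `COc1ccc(-c2cc3ccccc3nc2/C=C/C(=O)c2cnc(N)nc2C)cc1` differs from compound 1 by 2-amino-4-methylpyrimidin-5-yl in place of 4-hydroxyphenyl on a carbonyl carbon. Going by the values given here, the one measured step at this place, a 1.0-fold lower number from compound 1 to compound 2 (0.01 log units; within the scatter), swapped one carbon ring for another and left the number unchanged; no measured step introduces a ring with hetero atoms. The change for compound 3 is therefore expected to stay near compound 1, as a 1.1-fold lower number from compound 1 to compound 3 (0.04 log units; within the scatter). Compound 3 is estimated at 3500 nM, between 1200 nM and 10000 nM.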

Compound 3, half-maximal inhibitory concentration: > 10000 nM
Compound 3: a limit, no number; the forecaster's own chance of this, stated with the estimate: 5%; at least 2.8-fold (0.45 log units) between middle value and limit.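

In this assay, compound 3 gives a limit and not a number: the limit of > 10000 nM in this assay, at which 1 of the 3 values shown sits.

This place on the carbonyl carbon therefore does respond to the ring it carries: the change to 2-amino-4-methylpyrimidin-5-yl gives an at least 2.5-fold higher number from compound 1 to compound 3 (0.41 log units; beyond the scatter) and an at least 2.6-fold higher number from compound 2 to compound 3 (0.41 log units; beyond the scatter). The earlier swap of one carbon ring for another gave no hint of this.

The compounds shown do not separate the effect of the ring nitrogens from that of the amine or the methyl group on that ring. Going by these compounds, how a simple pyridine ring, or a phenyl ring carrying a carboxylic acid, would read here also stays open.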